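This account rests on a few compounds, and the source may have more. Where it says the series, first, only, none or still open, it means among the compounds named here.

The three measured compounds, each with its result in the same test:

Compound 1, `O=S1(=O)C=C(OCc2ccccc2)C(Cc2ccccc2)(Cc2ccccc2)O1`: in an ADME assay on HEL cells (Homo sapiens) for cytotoxicity, with a stated time of 3 days (on this read-out higher numbers stand for lower toxicity in this test and lower numbers for higher toxicity in this test), compound 1 gives 200000 nM.
Compound 2, `CCC1(Cc2ccccc2)OS(=O)(=O)C=C1OCc1ccccc1`: in this assay compound 2 gives 200000 nM.
Compound 3, `CC1(Cc2ccccc2)OS(=O)(=O)C=C1OCc1ccccc1`: in this assay compound 3 gives 68000 nM.

Compound 3 stands lowest of the three, meaning it is the most toxic of them on this read-out; its gap to each of the other two is beyond the scatter. Compound 4, `CCCC1(Cc2ccccc2)OS(=O)(=O)C=C1OCc1ccccc1`, is the next compound to be measured. It differs from compound 3 in one place: ethyl in place of hydrogen on a saturated chain carbon bound to a saturated ring carbon. Cut one bond further out, the same change reads methyl to propyl.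

Going by the values given here, two measured steps bear on this. Going the other way along this chain, a 2.9-fold lower number from compound 2 to compound 3 (0.47 log units; beyond the scatter), while no change at the digits printed from compound 1 to compound 2 (within the scatter). Both suggest that any group larger than hydrogen at this position returns the number to the higher level, and that the size of that group beyond methyl matters little. The step from compound 3 to compound 4 is therefore expected to raise the number by about a 2.6-fold higher number from compound 3 to compound 4 (0.42 log units; beyond the scatter). For compound 4 the estimate in this assay is 180000 nM, with a range from 70000 nM to 400000 nM.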

Compound 4, half-maximal cytotoxic concentration: 200000 nM
Compound 4: middle estimate off by 1.1-fold (0.05 log units), on the low side; the range from low to high includes it.
By their numbers in this assay, from the lowest: compound 3; then compounds 1, 2 and 4 (each within the scatter of the next).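

In this assay, changing methyl to propyl at this position gives a 2.9-fold higher number from compound 3 to compound 4 (0.47 log units; beyond the scatter) and so puts a third, different group alongside the two that already gave the higher number. Adding one more carbon to the chain of compound 2 gives no change at the digits printed from compound 2 to compound 4 (within the scatter), and ethyl in place of phenyl on the saturated chain carbon gives no change at the digits printed from compound 1 to compound 4 (within the scatter), so the chain's end can change from methyl to phenyl with no difference that can be read. Among these four compounds, the pattern is that the ethyl, propyl and benzyl-type side groups read alike, while compound 3, with the shortest group, is the one exception, and nothing shown here gives a reason for this.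

The compounds shown leave open whether a longer chain, such as butyl or hexyl, or a branched one, such as isopropyl, would stay at the same level in this test. They also do not tell what an amine or a carboxylic acid at the end of the chain would do, or whether a group smaller than methyl, such as a lone hydrogen on the ring carbon, would lower the number further.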